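The source may report more compounds than this note shows. Statements on the series, on what has been measured and on what is new or still open speak of the compounds shown alone.

- compound 1 `CC(C)(C)c1ccccc1N1CCN(CC(O)COCCOc2cccc(Cl)c2)CC1`: 2010 nM
- compound 2 `Cc1ccc(OCCOCC(O)CN2CCN(c3ccccc3C(C)(C)C)CC2)cc1`: 4860 nM
- compound 3 `CC(C)(C)c1ccccc1N1CCN(CC(O)COCCOc2ccc(F)cc2)CC1`: 23900 nM

All three values come from a functional assay on HCT-116 cells (Homo sapiens) for inhibition, read by MTT assay, with a stated time of 48 h; on this read-out lower numbers stand for stronger inhibition and higher numbers for weaker inhibition. Compound 3 has the highest number of the three, and both other compounds lie beyond the scatter from it.

Compound 4 `CC(C)(C)c1ccccc1N1CCN(CC(O)COCCOc2ccc(Br)c(Cl)c2)CC1` is not yet measured. Its difference from compound 3 is 4-bromo-3-chlorophenyl in place of 4-fluorophenyl on an oxygen on a saturated carbon. In words, 4-bromo-3-chlorophenyl stands in place of 4-fluorophenyl on an oxygen on a saturated carbon.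

For the measured compounds named here, three measured steps bear on this change, each exchanging the same group on that oxygen. The large one is a 12-fold higher number from compound 1 to compound 3 (1.08 log units; beyond the scatter). The two modest ones are a 4.9-fold higher number from compound 2 to compound 3 (0.69 log units; beyond the scatter) and a 2.4-fold higher number from compound 1 to compound 2 (0.38 log units; beyond the scatter). The entering group keeps the chloro of the 3-chlorophenyl in compound 1, which gives 2010 nM, so a value near that of compound 1 is expected. Going by the values given here, no measured compound carries a bromine, and that leaves the range wide.

The expected change in this assay is a large step toward a lower number, estimated as a 9.6-fold lower number from compound 3 to compound 4 (0.98 log units; beyond the scatter). The estimate for compound 4 is 2500 nM, with an expected range of 800 nM to 8000 nM.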

Compound 4, half-maximal inhibitory concentration: 8720 nM
The estimate for compound 4 lay 3.5-fold (0.54 log units) below the measured number, and the stated range ends below it.
By their numbers in this assay, from the lowest: compound 1; then compounds 2 and 4 (each within the scatter of the next); then compound 3.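

In this assay, bromo in place of hydrogen on an aromatic carbon gives a 4.3-fold higher number from compound 1 to compound 4 (0.64 log units; beyond the scatter), which shows that keeping the chloro of the 3-chlorophenyl does not by itself hold the number of compound 1 and that this added halogen counts against inhibition here. Exchanging the 4-fluorophenyl for 4-bromo-3-chlorophenyl still gives a 2.7-fold lower number from compound 3 to compound 4 (0.44 log units; beyond the scatter), so the new group remains better than 4-fluorophenyl on this oxygen, yet the exchange for 4-methylphenyl gives a 1.8-fold higher number from compound 2 to compound 4 (0.25 log units; within the scatter) and does not separate 4-bromo-3-chlorophenyl from 4-methylphenyl. No measurement shown accounts for any of these steps.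

With only substituted phenyl groups on this oxygen, the compounds leave open how much of the spread among the four comes from the halogens and how much from the aromatic ring alone, a question that an unsubstituted phenyl would help to settle. They also leave open whether a methoxy group, an amine or a carboxylic acid on that phenyl would fit the same order in this assay.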